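A few compounds are considered here, and "the series" means these few. Any claim that something is new, unique, unknown or untested is made for them only; others in the source may bear on it.

Measured compounds:
compound 1 `CCOC(=O)[C@@H](N)CCC(=O)NCCSC(=O)C(C)(C)C` gives 0.167 h in an ADME assay on liver for metabolic stability, with liver carboxylesterase 1 (Homo sapiens) as the target; on this read-out higher numbers stand for a longer-lived compound and lower numbers for a shorter-lived compound;
compound 2 `CCCCOC(=O)[C@@H](N)CCC(=O)NCCSC(=O)C(C)(C)C` gives 0.167 h in this assay;
compound 3 `CCCOC(=O)[C@@H](N)CCC(=O)NCCSC(C)=O` gives 0.167 h in this assay.

Compound 3 stands level with compounds 1 and 2 at the digits recorded; the differences to both lie within the scatter, so no order among the three can be read from the numbers.

The next compound is compound 4 `CCCOC(=O)[C@@H](N)CCC(=O)NCCSC(=O)C(C)(C)C`, which is still to be measured in this assay. Relative to compound 3 the difference is tert-butyl in place of methyl on a carbonyl carbon, the carbonyl carbon in question having sulfur as its other neighbour; cut one bond further out, the same change reads acetylsulfanyl to ((tert-butyl)carbonyl)sulfanyl.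

For the measured compounds named here, only one measured step is available, no change at the digits printed from compound 1 to compound 2 (within the scatter), and it concerns the ester chain rather than the thioester carbonyl, so it does not bear directly on the change. What does bear on it is that compounds 1 and 2, which already carry the tert-butyl group at this position, sit at the same value as compound 3. No step beyond the scatter is therefore expected in this assay.

For compound 4 the expected step is no change at the digits printed from compound 3 to compound 4 (within the scatter), and the estimated half-life is 0.167 h, in the range 0.08 h to 0.35 h.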

Compound 4, half-life: 0.167 h
Compound 4: the middle estimate sits on the measured number at the digits printed, within the range that was stated.
By their numbers in this assay, from the lowest: compounds 1, 2, 3 and 4 (each within the scatter of the next).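

In this assay the change on a carbonyl carbon whose other neighbour is sulfur can now be read directly, and tert-butyl in place of methyl gives no change at the digits printed from compound 3 to compound 4 (within the scatter) even though the entering group holds 4 heavy atoms against 1 for the one leaving. The ester chain can also now be read in two further single-place steps on the tert-butyl thioester, with methyl in place of hydrogen on a saturated chain carbon giving no change at the digits printed from compound 1 to compound 4 (within the scatter) and hydrogen in place of methyl on a saturated chain carbon giving no change at the digits printed from compound 2 to compound 4 (within the scatter), so neither change separates these compounds. No measurement at hand speaks to what lies behind these level readings.

With all four compounds printing the same number, the set does not show whether any change at either place can move the half-life at all. As far as these compounds go, how a phenyl group on the thioester carbonyl, an amide in place of the thioester, or a carboxylic acid in place of the ester would read remains open.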